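The compounds below may be only part of what the source reports. "The series", "measured", "known", "first", "only" and "open" are said of these compounds alone.

Measured in a functional assay on MCF7 cells (Homo sapiens) for antiproliferative activity; a lower number here means a stronger inhibitor, a higher number a weaker inhibitor:
- compound 1 `O=C(Nc1ccc(O)c2c(=O)cc(-c3ccccc3Cl)oc12)c1ccccc1`: 7100 nM
- compound 2 `C[C@@H](NC(=O)OC(C)(C)C)C(=O)Nc1ccc(O)c2c(=O)cc(-c3ccccc3Cl)oc12`: 5500 nM
- compound 3 `CC(C)C[C@@H](NC(=O)OC(C)(C)C)C(=O)Nc1ccc(O)c2c(=O)cc(-c3ccccc3Cl)oc12`: 2500 nM

Compound 3 has the lowest number of the three. Its value lies beyond the scatter of both others, though the whole series spans a narrow range. The next compound, compound 4 `CSCC[C@@H](NC(=O)OC(C)(C)C)C(=O)Nc1ccc(O)c2c(=O)cc(-c3ccccc3Cl)oc12`, keeps the shared core and the tert-butoxycarbonyl amino group of compound 3. It differs at one place: (methylsulfanyl)methyl in place of isopropyl on a saturated chain carbon, two bonds along the chain from an amide-type nitrogen and a carbonyl carbon. In words, (methylsulfanyl)methyl stands in place of isopropyl on a saturated chain carbon, two bonds along the chain from an amide-type nitrogen and a carbonyl carbon.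

Within the data shown here, two measured steps bear on this only loosely. The change on the carbonyl carbon, a 1.3-fold lower number from compound 1 to compound 2 (0.11 log units; within the scatter), is small. Among the measured compounds shown here, the one step at the place in question, a 2.2-fold lower number from compound 2 to compound 3 (0.34 log units; beyond the scatter), is modest, and it put isopropyl in place of hydrogen. For the measured compounds named here, no measured compound carries the entering group, so the data hold no direct precedent for the swap. Resting on compound 3 at 2500 nM, only a small change in this assay is expected, with no shift beyond the scatter and a slight lean toward a higher number. The estimated change is a 1.2-fold higher number from compound 3 to compound 4 (0.08 log units; within the scatter). For compound 4 the expected value is 3000 nM, with an estimated range of 1300 nM to 7000 nM.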

Compound 4, half-maximal inhibitory concentration: 2800 nM
Beside the measured number, compound 4's estimate is 1.1-fold (0.03 log units) above it; the range from low to high includes it.
By their numbers in this assay, from the lowest: compounds 3, 4, 2 and 1 (each within the scatter of the next, the first and the last beyond it).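

In this assay, the exchange of isopropyl for (methylsulfanyl)methyl on the saturated chain carbon, two bonds along the chain from an amide-type nitrogen and a carbonyl carbon, gives a 1.1-fold higher number from compound 3 to compound 4 (0.05 log units; within the scatter), so a group bringing sulfur and a hydrogen-bond acceptor leaves compound 4 indistinguishable from compound 3 in this read-out. Measured against hydrogen at the same place, the entering group gives a 2.0-fold lower number from compound 2 to compound 4 (0.29 log units; within the scatter), while isopropyl gave a 2.2-fold lower number from compound 2 to compound 3 (0.34 log units; beyond the scatter), so only the isopropyl step clears the scatter, and by a thin margin, even though the two groups cannot be separated from each other. The data offer no evidence that would explain these results.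

The compounds shown leave open how an amine or a carboxylic acid at the end of this side chain would read in this assay, and whether a phenyl ring or a longer chain at the same place would move the number beyond the scatter of compound 3. They also leave open whether the side-chain result would hold with a free amine in place of the tert-butoxycarbonyl amino group.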